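Swapping a pyridyl for a methoxyphenyl on the chain

This account rests on a few compounds, and the source may have more. Where it says the series, first, only, none or still open, it means among the compounds named here.

Compound 1 `O[C@@H](c1ccccc1)[C@H]1CO[C@H](c2ccccc2)[C@@H](C/C=C/c2ccccn2)C1` carries, on its shared core, a short double-bonded chain that ends in a pyridin-2-yl ring. In a functional assay on HeLa cells (Homo sapiens) for cytotoxicity, read by WST assay, with a stated time of 48 h (a lower number here means a stronger inhibitor, a higher number a weaker inhibitor), compound 1 gives 33800 nM. Compound 2 `COc1cccc([C@H]2OC[C@H]([C@@H](O)c3ccc(OC)c(OC)c3)C[C@@H]2C/C=C/c2ccc(OC)c(OC)c2)c1` is a relative whose chain and aryl groups carry methoxy groups; in this assay compound 2 gives 21800 nM, and the two numbers lie within the usual scatter of each other, so neither compound can be called the stronger of the pair. Compound 3 `COc1cccc(/C=C/C[C@H]2C[C@@H]([C@@H](O)c3ccccc3)CO[C@@H]2c2ccccc2)c1` is compound 1 with a single change: 3-methoxyphenyl in place of pyridin-2-yl on a double-bonded chain carbon bound to a double-bonded chain carbon. Because compound 2 with 21800 nM shows that a methoxy-bearing aryl ring on the chain leaves the number in the same region, no step beyond the scatter is expected in either direction. Compound 3 is therefore expected to give about 26000 nM, with a range from 9000 nM to 75000 nM. That would amount to an expected step of a 1.3-fold lower number from compound 1 to compound 3 (0.11 log units; within the scatter).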

Compound 3, half-maximal inhibitory concentration: 10900 nM
Compound 3: middle estimate off by 2.4-fold (0.38 log units), on the high side; low and high end bracket the measured number.
By their numbers in this assay, from the lowest: compounds 3, 2 and 1 (each within the scatter of the next, the first and the last beyond it).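

In this assay the change from pyridin-2-yl to 3-methoxyphenyl on the chain gives a 3.1-fold lower number from compound 1 to compound 3 (0.49 log units; beyond the scatter) and so counts as a real, if modest, step. Compound 2 differs from compound 1 in several places and could not isolate the chain-end ring, whereas this single change shows that the ring alone can move the number while the rest of the molecule stays the same. Nothing measured here accounts for the step.

This change removes a ring nitrogen and adds a methoxy group at once, so the compounds shown cannot separate the two. A plain phenyl ring at the same chain end would help to tell them apart, and an amine on that ring would test whether a different kind of group moves the number too.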